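The source may report more compounds than this note shows. Statements on the series, on what has been measured and on what is new or still open speak of the compounds shown alone.

Compound 1 `Cc1ccccc1Cn1ccc2nc(-c3ccccc3)nc-2c1`, compound 2 `COc1ccc(Cn2ccc3nc(-c4ccccc4)nc-3c2)cc1` and compound 3 `Clc1cccc(Cn2ccc3nc(-c4ccccc4)nc-3c2)c1` share one core and differ only in the group on a saturated chain carbon bound to an aromatic nitrogen. In an ADME assay on MDBK cells (Bos taurus) for cytotoxicity (a higher number here means that more compound is tolerated, a lower number that less compound is tolerated), compound 1 gives a value that is a limit, > 100000 nM. Compound 2 likewise reaches only the limit of > 100000 nM. Compound 3 too stops at the limit of > 100000 nM, so its place among the three cannot be read. The steps a step that the two limits leave unreadable from compound 1 to compound 2, a step that the two limits leave unreadable from compound 1 to compound 3 and a step that the two limits leave unreadable from compound 2 to compound 3 are all of unreadable size, since every value shown sits at the limit of > 100000 nM in this assay, at which 3 of the 3 values shown sit. Compound 4 `c1ccc(-c2nc3ccn(CC4CCCCC4)cc-3n2)cc1` carries cyclohexyl in place of 3-chlorophenyl on a saturated chain carbon bound to an aromatic nitrogen. For the measured compounds named here, no measured step shows a readable size, so a step that the limit leaves unreadable from compound 3 to compound 4 is expected, within the scatter. Compound 4 is therefore estimated at 120000 nM, between 40000 nM and 300000 nM.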

Compound 4, half-maximal cytotoxic concentration: > 100000 nM
Compound 4: only a limit was reported; the forecaster's own chance of this, stated with the estimate: 80%; the middle value does not contradict the limit.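

In this assay compound 4 also stops at a limit, so its steps from compound 1, compound 2 and compound 3 cannot be read: the limit of > 100000 nM in this assay, at which 4 of the 4 values shown sit.

The compounds shown leave open whether these groups differ at all in this assay.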